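A trifluoromethyl-to-dimethylcarbamoyl swap on the shared core

A few compounds are considered here, and "the series" means these few. Any claim that something is new, unique, unknown or untested is made for them only; others in the source may bear on it.

Measured in an assay on HEK-293T cells for inhibition of diacylglycerol lipase-alpha (Homo sapiens), read by colorimetric assay; a higher number here means a weaker inhibitor, a lower number a stronger inhibitor:
Compound 1, `O=C(CCCCCc1ccccc1)c1nc2ccc([N+](=O)[O-])cc2o1`: 87.1 nM
Compound 2, `O=C(CCCCCCc1ccccc1)c1nnn(-c2ccco2)n1`: only a limit of the assay, > 10000 nM
Compound 3, `O=C(CCCCCCc1ccccc1)c1nc(C(F)(F)F)co1`: 214 nM

Among the two numbers, compound 3 stands at the highest, meaning the weaker inhibitor; compound 1 sits at a lower number, and that gap lies beyond the usual scatter. Compound 2 reached only the limit of the assay, (the limit of > 10000 nM in this assay, at which 1 of the 3 values shown sits).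

Compound 4, `CN(C)C(=O)c1coc(C(=O)CCCCCCc2ccccc2)n1`, differs from compound 3 by dimethylcarbamoyl in place of trifluoromethyl on an aromatic carbon. Going by the values given here, no measured pair shows this change, so the size of the step in this assay is open; a modest move toward a higher number is expected, a 2.3-fold higher number from compound 3 to compound 4 (0.37 log units; beyond the scatter). Compound 4 is therefore estimated at 500 nM, with a range from 120 nM to 3000 nM.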

Compound 4, half-maximal inhibitory concentration: 3390 nM
Estimate against measurement, compound 4: 6.8-fold (0.83 log units) below; the measured number lies above the stated range.
By their numbers in this assay, from the lowest: compound 1; then compound 3; then compound 4. At a limit, above all of these: compound 2.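

In this assay the group on this aromatic carbon, next to the ring nitrogen, clearly matters: dimethylcarbamoyl in place of trifluoromethyl gives a 16-fold higher number from compound 3 to compound 4 (1.20 log units; beyond the scatter) and so a much weaker inhibitor. Going by these compounds alone, this is the only pair here that differs in one place, so it is the first direct reading of this position. Nothing measured here accounts for the size of this step.

As far as these compounds go, whether a nitrile or a carboxylic acid on this carbon would fall nearer compound 3 or compound 4 stays open. From the compounds shown here alone, whether the same swap would have a similar effect on another core also stays open.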